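More Fluoro on Compound 1: What to Expect

The source may hold more compounds than are shown below. What is called first, only, known or untested is meant among the compounds shown, and "the series" means these compounds.

Measured in a functional assay on PBMC cells (Homo sapiens) for inhibition, read by ELISA, BrdU incorporation and thymidine incorporation, with a stated time of 72 h; on this read-out higher numbers stand for weaker inhibition and lower numbers for stronger inhibition:
- Compound 1 `CC/C(O)=C(\C#N)C(=O)Nc1ccc(-c2ccc(F)cc2)c(C(=O)OC)c1`: 2000 nM
- Compound 2 `CC/C(O)=C(\C#N)C(=O)Nc1ccc(-c2ccc(F)cc2F)c(C(=O)OC)c1`: 6000 nM

Of these two numbers, compound 1 holds the lower, 2000 nM, which marks it as the stronger inhibitor. Compound 3 `CC/C(O)=C(\C#N)C(=O)Nc1ccc(-c2cc(F)c(F)c(F)c2)c(C(=O)OC)c1` is still unmeasured. Its change is 3,4,5-trifluorophenyl in place of 4-fluorophenyl on an aromatic carbon, with 3,4,5-trifluorophenyl in place of 4-fluorophenyl on an aromatic carbon. Within the data shown here, the only measured step that bears on this is a 3.0-fold higher number from compound 1 to compound 2 (0.48 log units; beyond the scatter), a modest one beyond the scatter, from fluoro in place of hydrogen on an aromatic carbon. One step is thin evidence, but a similar modest move towards weaker inhibition is expected in this assay. The expected step is a 2.3-fold higher number from compound 1 to compound 3 (0.35 log units; beyond the scatter). Compound 3 is estimated at 4500 nM, with a range from 1300 nM to 15000 nM.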

Compound 3, half-maximal inhibitory concentration: 19000 nM
Beside the measured number, compound 3's estimate is 4.2-fold (0.63 log units) below it, outside the stated range (above it).
By their numbers in this assay, from the lowest: compound 1; then compound 2; then compound 3.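

At this position, 3,4,5-trifluorophenyl gives the weakest inhibition of the three in this assay, with a 9.5-fold higher number from compound 1 to compound 3 (0.98 log units; beyond the scatter) and a 3.2-fold higher number from compound 2 to compound 3 (0.50 log units; beyond the scatter). Across these three compounds, the number rises with each added fluorine, and none goes against this order. Nothing here explains the loss.

Still open, going by these compounds, is whether the count of fluorines or their placement matters more, as the 2,4-difluorophenyl and 3,4,5-trifluorophenyl groups differ in both. On these data alone, how an unsubstituted phenyl or a 4-chlorophenyl group would behave here also remains unknown.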